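Ester variation on the shared core: hydroxy(phenyl)methyl replaces 1-ethyl-1-hydroxypropyl

The compounds below may be only part of what the source reports. "The series", "measured", "known", "first", "only" and "open" are said of these compounds alone.

The series keeps one core and varies the acyl group of the ester. In a functional assay on HeLa cells (Homo sapiens) for cytotoxicity, read by MTT assay (on this read-out higher numbers stand for weaker inhibition and lower numbers for stronger inhibition), compound 1 `CC(C)=CC[C@@H](OC(=O)C1CCCO1)C1=CC(=O)c2c(O)ccc(O)c2C1=O` gives 17000 nM. Within the data shown here, compound 2 `CCC(O)(CC)CC(=O)O[C@H](CC=C(C)C)C1=CC(=O)c2c(O)ccc(O)c2C1=O` gives 52000 nM in this assay, the higher of the two numbers so far; the only step measured, a 3.1-fold higher number from compound 1 to compound 2 (0.49 log units; beyond the scatter), is the one that separates it from compound 1.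

Compound 3 `CC(C)=CC[C@@H](OC(=O)CC(O)c1ccccc1)C1=CC(=O)c2c(O)ccc(O)c2C1=O` differs from compound 2 by hydroxy(phenyl)methyl in place of 1-ethyl-1-hydroxypropyl on a saturated chain carbon bound to a carbonyl carbon. Among the measured compounds shown here, no measured step covers this change: the one step known, a 3.1-fold higher number from compound 1 to compound 2 (0.49 log units; beyond the scatter), exchanges a ring for an open hydroxy-bearing chain on the carbonyl carbon, whereas here the hydroxy-bearing chain stays and an aromatic ring enters. Without direct precedent the expectation for this assay is a small shift, a 1.7-fold lower number from compound 2 to compound 3 (0.24 log units; within the scatter), toward a somewhat lower number rather than a large move. Compound 3 is therefore estimated at 30000 nM, with a range from 10000 nM to 90000 nM.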

Compound 3, half-maximal inhibitory concentration: 44500 nM
Estimate against measurement, compound 3: 1.5-fold (0.17 log units) below, and the stated range covers the measured number.
By their numbers in this assay, from the lowest: compound 1; then compounds 3 and 2 (each within the scatter of the next).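

In this assay, hydroxy(phenyl)methyl in place of 1-ethyl-1-hydroxypropyl on a saturated chain carbon bound to a carbonyl carbon gives a 1.2-fold lower number from compound 2 to compound 3 (0.07 log units; within the scatter) and so does not separate these two open hydroxy-bearing chains, one with an aromatic ring and one without. The second open chain also stands apart from oxolan-2-yl, with 2-hydroxy-2-phenylethyl on a carbonyl carbon giving a 2.6-fold higher number from compound 1 to compound 3 (0.42 log units; beyond the scatter) and 2-ethyl-2-hydroxybutyl giving a 3.1-fold higher number from compound 1 to compound 2 (0.49 log units; beyond the scatter) in the same direction. No supporting data accompany these results to account for either step.

Still open, as far as these compounds go, is whether the ring of oxolan-2-yl or the free hydroxy on the open chains separates compound 1 from compound 2 and compound 3. Also open, from the compounds shown here alone, is how an amine or a carboxylic acid in place of that hydroxy, or a longer chain, would read in this assay on this ester.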